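Swapping the Hydrazone Substituent on a Shared Core

This account rests on a few compounds, and the source may have more. Where it says the series, first, only, none or still open, it means among the compounds named here.

Measured compounds:
compound 1, `CCOC(=O)C1=C(N/N=C(/C#N)C(=O)OCC)Nc2[nH]nc(C)c2C1c1ccc(N(C)C)cc1`: 39200 nM
compound 2, `CCOC(=O)C1=C(N/N=C(\C#N)C(N)=O)Nc2[nH]nc(C)c2C1c1ccc(N(C)C)cc1`: 47300 nM
compound 3, `CCOC(=O)C1=C(NN=C(C#N)C#N)Nc2[nH]nc(C)c2C1c1ccc(N(C)C)cc1`: 15200 nM

In a functional assay on HeLa cells (Homo sapiens) for inhibition, read by MTT assay, with a stated time of 48 h (on this read-out higher numbers stand for weaker inhibition and lower numbers for stronger inhibition), compound 1 gives the second highest of the three numbers. Its nearest neighbour is compound 2, reached by a 1.2-fold higher number from compound 1 to compound 2 (0.08 log units; within the scatter), while compound 3 lies furthest away, reached by a 2.6-fold lower number from compound 1 to compound 3 (0.41 log units; beyond the scatter). Compound 2 and compound 3 are separated by a 3.1-fold lower number from compound 2 to compound 3 (0.49 log units; beyond the scatter).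

Compound 4, `CCOC(=O)C1=C(N/N=C(/Br)c2ccccc2)Nc2[nH]nc(C)c2C1c1ccc(N(C)C)cc1`, has not yet been measured in this assay. Its change from compound 1 is a group of 9 heavy atoms (7 carbon, 1 nitrogen, 1 bromine; one six-membered aromatic ring of carbon only) in place of a group of 9 heavy atoms (5 carbon, 2 nitrogen, 2 oxygen; no ring), on an amine nitrogen. Among the compounds with values here, all three measured steps alter the group on this same amine nitrogen, yet none of them introduces a ring or a bromine, so no measured step matches this change directly. What they show is that rearranging this group moves the number only modestly, in either direction, and sometimes not beyond the scatter. On that basis the step of a 1.3-fold lower number from compound 1 to compound 4 (0.12 log units; within the scatter) is expected to stay modest, with no confident direction. Compound 4 is therefore estimated at 30000 nM, within a range from 8000 nM to 110000 nM.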

Compound 4, half-maximal inhibitory concentration: 75700 nM
For compound 4 the middle estimate is 2.5-fold (0.40 log units) below the measured one; measured number inside the range.
By their numbers in this assay, from the lowest: compound 3; then compounds 1, 2 and 4 (each within the scatter of the next).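

Replacing the ring-free group of compound 1 with one carrying a six-membered aromatic ring and a bromine, with no triple bond and fewer hydrogen-bond acceptors, leaves the reading in this assay close to where it was: a 1.9-fold higher number from compound 1 to compound 4 (0.29 log units; within the scatter), and likewise a 1.6-fold higher number from compound 2 to compound 4 (0.20 log units; within the scatter). This position on the amine nitrogen therefore accepts a group of quite different make-up without a change beyond the scatter, whereas the group of compound 3 does stand apart, with a 5.0-fold higher number from compound 3 to compound 4 (0.70 log units; beyond the scatter), and compound 3 remains the most potent of the four, its steps to all the others lying beyond the scatter. Nothing available here bears on why these groups give these numbers.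

Compound 4 brings in the bromine and the benzene ring together, so the compounds shown cannot separate what each contributes, and a version with chlorine or hydrogen in place of the bromine would be needed to do that. Also open, from the compounds shown here alone, is how a saturated ring such as piperidine, an amine or a carboxylic acid would read on this same group.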